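Replacing the Diethylaminoethyl Arm with Phenyl

The source may report more compounds than this note shows. Statements on the series, on what has been measured and on what is new or still open speak of the compounds shown alone.

Compound 1 `CN(C)CCCNC1=Nc2ccc(Cl)cc2C(C)(C)C1`: 38%
Compound 2 `CCN(CC)CCCNC1=Nc2ccc(Cl)cc2C(C)(C)C1`: 36.1%

In a functional assay on MDA-MB-231 cells (Homo sapiens) for cytotoxicity, read by MTT assay, with a stated time of 72 h, tested at 5 uM, in the absence of a further agent (a lower number here means a stronger effect, a higher number a weaker effect of the compound at the concentration tested), compound 2 and compound 1 give numbers that lie within the scatter of each other, so the two are not told apart. Compound 3 `CC1(C)CC(NCc2ccccc2)=Nc2ccc(Cl)cc21` differs from compound 2 by phenyl in place of 2-(diethylamino)ethyl on a saturated chain carbon bound to an amine nitrogen. Within the data shown here, the only measured step, a number 1.9 percentage points lower from compound 1 to compound 2 (within the scatter), changed the amine three bonds along the chain and stayed within the scatter; the change to compound 3 instead removes the whole 2-(diethylamino)ethyl group, so that step gives little guidance on size or direction. Compound 3 is therefore expected to give 45% (from 25% to 70%), an estimated step of a number 8.9 percentage points higher from compound 2 to compound 3 (within the scatter) with wide uncertainty.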

Compound 3, a percentage reported as activity, at one concentration (the size of the read-out at that concentration, not a potency): 68.1%
Estimate against measurement, compound 3: 23.1 percentage points below; the measured number falls inside the stated range.
By their numbers in this assay, from the lowest: compounds 2 and 1 (each within the scatter of the next); then compound 3.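

In this assay, a number 32 percentage points higher from compound 2 to compound 3 (beyond the scatter) and a number 30.1 percentage points higher from compound 1 to compound 3 (beyond the scatter) follow when phenyl replaces the amine-bearing arm on a saturated chain carbon bound to an amine nitrogen. Thus, while exchanging diethylamino for dimethylamino left compounds 1 and 2 untold apart, replacing the whole arm clearly weakens the effect at this place. Going by these compounds, it remains open whether a terminal amine is what matters: a morpholine or piperidine on the same chain, or a phenyl on a longer chain, would separate the amine from chain length. Nothing available explains the difference.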